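A narrow solubility series and one amide substituent change

The compounds below may be only part of what the source reports. "The series", "measured", "known", "first", "only" and "open" are said of these compounds alone.

In a physicochemical assay for solubility, read by spectrophotometry, measured as kinetic solubility, at pH 8, tested at 500 uM (on this read-out lower numbers stand for lower solubility and higher numbers for higher solubility), compound 1 (`CN(C)C(=O)c1ccncc1Nc1cc(-c2ccc3ccn(C)c3c2)c2nccnc2c1`) gives 175 ug/mL and compound 2 (`Cn1cc(CNC(=O)c2ccncc2Nc2cc(-c3ccc4ccn(C)c4c3)c3nccnc3c2)cn1`) gives 127 ug/mL while compound 3 (`CN1CC(NC(=O)c2ccncc2Nc2cc(-c3ccc4ccn(C)c4c3)c3nccnc3c2)C1`) gives 170 ug/mL on the same shared core. These three values lie within the scatter of one another, so compound 3 holds no separate place among them.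

Compound 4 (`CN1CCC(CNC(=O)c2ccncc2Nc2cc(-c3ccc4ccn(C)c4c3)c3nccnc3c2)C1`) differs from compound 3 on an amide-type nitrogen whose other neighbour is the carbonyl carbon ((1-methylpyrrolidin-3-yl)methyl in place of 1-methylazetidin-3-yl on an amide-type nitrogen). The measured steps at this place are small: the series shows a 1.4-fold lower number from compound 1 to compound 2 (0.14 log units; within the scatter) and a 1.0-fold lower number from compound 1 to compound 3 (0.01 log units; within the scatter) and also a 1.3-fold higher number from compound 2 to compound 3 (0.13 log units; within the scatter) with each lying within the scatter. Among the measured compounds shown here, no measured compound carries the (1-methylpyrrolidin-3-yl)methyl group, so the expectation rests on those steps alone.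

In this assay the expected step is a 1.1-fold lower number from compound 3 to compound 4 (0.03 log units; within the scatter) which means none beyond the scatter and no favoured direction. For compound 4 the estimated value is 160 ug/mL with 95 ug/mL to 240 ug/mL as the expected range.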

Compound 4, solubility: 246 ug/mL
Estimate against measurement, compound 4: 1.5-fold (0.19 log units) below; the whole stated range lies below it.
By their numbers in this assay, from the lowest: compounds 2, 3, 1 and 4 (each within the scatter of the next).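

Among the compounds shown here, with (1-methylpyrrolidin-3-yl)methyl on the amide-type nitrogen, this assay gives a 1.4-fold higher number from compound 3 to compound 4 (0.16 log units; within the scatter) and a 1.9-fold higher number from compound 2 to compound 4 (0.29 log units; within the scatter) and also a 1.4-fold higher number from compound 1 to compound 4 (0.15 log units; within the scatter) with no step leaving the scatter. The larger saturated group therefore extends the range of substituents at this place, from a four-membered to a five-membered non-aromatic ring carried on a methyl link, without separating compound 4 from any earlier compound. Nothing in the available data accounts for these readings.

As far as these compounds go, whether a carboxylic acid or an open-chain dimethylaminoethyl group on the same amide-type nitrogen would give a step beyond the scatter remains open. The compounds shown also leave open whether the same substituents would stay this close together at a pH other than the one used here.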